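The source may report more compounds than this note shows. Statements on the series, on what has been measured and on what is new or still open speak of the compounds shown alone.

In a functional assay on MCF7 cells (Homo sapiens) for antiproliferative activity, read by sulforhodamine B assay, with a stated time of 72 h (a higher number here means a weaker inhibitor, a lower number a stronger inhibitor), compound 1 `Fc1ccc(Nc2nncc3ccccc23)cc1` gives 3.5 nM, and compound 2 `NS(=O)(=O)c1ccc(Nc2nncc3ccccc23)cc1` gives 37 nM. Compound 2 therefore holds the higher of the two numbers and is the weaker inhibitor of the pair. The next compound, compound 3 `N#Cc1ccc(Nc2nncc3ccccc23)cc1`, has cyano in place of sulfamoyl on an aromatic carbon. Going by the values given here, only one measured step bears on this change: an 11-fold higher number from compound 1 to compound 2 (1.02 log units; beyond the scatter). It is large, lies beyond the scatter and involves the same substituent place, with sulfamoyl entering where fluoro leaves. Among the compounds with values here, no measured compound yet shows what cyano does here, so this step offers only a rough guide. Removing sulfamoyl is expected to recover part of that loss, but not necessarily all of it. The step expected in this assay is therefore moderate and toward a lower number: a 3.1-fold lower number from compound 2 to compound 3 (0.49 log units; beyond the scatter). For compound 3 the estimated value is 12 nM, with an expected range from 3.5 nM to 40 nM.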

Compound 3, half-maximal inhibitory concentration: 2.3 nM
The estimate for compound 3 lay 5.2-fold (0.72 log units) above the measured number; measured number outside the range, below it.
By their numbers in this assay, from the lowest: compounds 3 and 1 (each within the scatter of the next); then compound 2.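

In this assay, replacing sulfamoyl with cyano on this aromatic carbon gives a 16-fold lower number from compound 2 to compound 3 (1.21 log units; beyond the scatter) and so takes the number back to the level of the fluoro compound, not just part of the way there. That comparison gives a 1.5-fold lower number from compound 1 to compound 3 (0.18 log units; within the scatter) and lies within the scatter, so cyano and fluoro cannot be told apart at this position, and among the three groups shown only sulfamoyl stands apart, with the weaker inhibition. Nothing measured here explains why sulfamoyl differs from the other two groups.

On these data alone, the three compounds cannot show which feature of sulfamoyl goes with the weaker inhibition, and it remains open whether a group such as an amine, a carboxylic acid or a methyl sulfone would fall with sulfamoyl or with cyano and fluoro. They also leave open whether the same ordering of these groups would hold on another carbon of that ring, since all three compounds carry their substituent in the same place on the shared core.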